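Para-substituted anilino series: fluoro to chloro exchange

The compounds below may be only part of what the source reports. "The series", "measured", "known", "first", "only" and "open" are said of these compounds alone.

Compound 1 `COc1ccc(C(=O)c2sc(Nc3ccccc3)c(C(=O)O)c2C)cc1` gives 52.6% in a functional assay, with a stated time of 150 min, tested at 25 ug/mL; a lower number here means a weaker effect, a higher number a stronger effect of the compound at the concentration tested. Compound 2 `COc1ccc(C(=O)c2sc(Nc3ccc(F)cc3)c(C(=O)O)c2C)cc1` gives 0.836% in this assay. Going by the values given here, the one measured step, a number 51.8 percentage points lower from compound 1 to compound 2 (beyond the scatter), arises from fluoro in place of hydrogen on an aromatic carbon. Among the compounds with values here, on the numbers so far compound 2 stands lowest of the two, with compound 1 the nearest and well beyond the scatter above it.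

Compound 3 `COc1ccc(C(=O)c2sc(Nc3ccc(Cl)cc3)c(C(=O)O)c2C)cc1` differs from compound 2 by chloro in place of fluoro on an aromatic carbon. Within the data shown here, no measured step covers this exchange of one halogen for another; the only step in hand, a number 51.8 percentage points lower from compound 1 to compound 2 (beyond the scatter), concerns the introduction of the para substituent, not its identity, so it bears on the question only indirectly. Given that compound 2 already sits near the floor of the read-out, a chloro in the same place is expected to give a small step, a number 4.2 percentage points higher from compound 2 to compound 3 (within the scatter), most likely within the scatter, with any larger movement expected upward rather than down. Compound 3 is therefore estimated at 5% in this assay, with a range from 0% to 30%.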

Compound 3, a percentage reported as activity, at one concentration (the size of the read-out at that concentration, not a potency): "not active" (no number reported)
Compound 3 has no reported number here; no gap can be computed for the estimate.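

Going by these compounds alone, compound 3 is reported as "not active" in this assay without a number, so no step from compound 2 to compound 3 can be read. The compounds shown leave open how the 4-chlorophenyl and 4-fluorophenyl analogues compare numerically, and whether any para substituent retains the effect of compound 1. Nothing available bears on this result.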